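A Bromine on the Other Ring of Compound 1

The compounds below may be only part of what the source reports. "The series", "measured", "known", "first", "only" and "open" are said of these compounds alone.

Three amides share one core and differ only in the ring attached to the carbonyl. Compound 1 `O=C(Nc1cc(-c2ccccc2)nn1-c1ccccc1)c1ccccc1` carries a plain phenyl there and stands highest of the three in an assay on HEK293 cells for displacement of a labelled ligand from metabotropic glutamate receptor 5 (Rattus norvegicus) (on this read-out higher numbers stand for weaker inhibition and lower numbers for stronger inhibition), where compound 1 gives 4180 nM. Compound 2 `O=C(Nc1cc(-c2ccccc2)nn1-c1ccccc1)c1ccc(C(F)(F)F)cc1` gives 990 nM and compound 3 `O=C(Nc1cc(-c2ccccc2)nn1-c1ccccc1)c1ccc(Cl)c(Cl)c1` gives 160 nM in this assay. Trifluoromethyl in place of hydrogen brought a 4.2-fold lower number from compound 1 to compound 2 (0.63 log units; beyond the scatter), the two chlorines brought a 26-fold lower number from compound 1 to compound 3 (1.42 log units; beyond the scatter), and between those two substituted rings the gap was a 6.2-fold lower number from compound 2 to compound 3 (0.79 log units; beyond the scatter).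

Compound 4 `O=C(Nc1cc(-c2ccccc2)nn1-c1cccc(Br)c1)c1ccccc1` differs from compound 1 by bromo in place of hydrogen on an aromatic carbon. This is not the ring that compounds 2 and 3 vary, so the measured steps bear on it only loosely: they show that halogens on one ring helped strongly, but give no direct reading for this one. A small improvement is therefore expected, about a 2.1-fold lower number from compound 1 to compound 4 (0.32 log units; beyond the scatter), with no change beyond the scatter also possible. For compound 4 the estimate in this assay is 2000 nM, within a range from 600 nM to 6000 nM.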

Compound 4, inhibition constant: > 10000 nM
Compound 4 gave a limit, no number (the forecaster's own chance of this, stated with the estimate: 5%); middle value at least 5.0-fold (0.69 log units) from the limit.
By their numbers in this assay, from the lowest: compound 3; then compound 2; then compound 1. At a limit, above all of these: compound 4.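

Bromo in place of hydrogen, meta to a large group on a ring that compounds 2 and 3 leave unchanged, brought an at least 2.3-fold higher number from compound 1 to compound 4 (0.37 log units; beyond the scatter) and so weakened inhibition, whereas the substituents on the ring attached to the carbonyl strengthened it. What helped on that ring therefore gives no guide to this one, at least for this single change. Compound 4 gives a limit of the assay and not a number: the limit of > 10000 nM in this assay, at which 1 of the 4 values shown sits.

With only bromo shown at this place, it remains open whether a fluorine atom, a methoxy group or an amine there would also weaken inhibition. From the compounds shown here alone, it is equally open whether bromo elsewhere on this ring would do the same, so one compound cannot show how the whole ring responds to substitution.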